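The source may hold more compounds than are shown below. What is called first, only, known or untested is meant among the compounds shown, and "the series" means these compounds.

Measured so far:
Compound 1 `CN1CCC[C@H]1COc1cccnc1Br`; in an assay on K177 cells for activation of Neuronal acetylcholine receptor; alpha4/beta2 (Homo sapiens) (a lower number here means that less compound is needed, a higher number that more compound is needed for the effect), compound 1 reports only the assay limit > 1000000 nM.
Compound 2 `Cc1ccc(OC[C@@H]2CCCN2C)cn1`; in this assay compound 2 gives 2200 nM.
Compound 3 `CN1CCC[C@H]1COc1ccc(Cl)nc1`; in this assay compound 3 gives 1400 nM.

Compound 3 has the lowest of the two numbers in this assay, but its nearest neighbour, compound 2, lies within the scatter of it, so no order between the two is claimed. Compound 1 stands apart as a limit of > 1000000 nM in this assay, at which 1 of the 3 values shown sits, and gives no number to compare against.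

The step to compound 4 `CN1CCC[C@H]1COc1ccc(Br)nc1` is bromo in place of chloro on an aromatic carbon. Going by the values given here, the only measured step at the same place is a 1.6-fold lower number from compound 2 to compound 3 (0.20 log units; within the scatter), where a chloro replaced a methyl and moved the number by less than the scatter. Among the compounds with values here, no step from chloro to bromo is measured anywhere; compound 1 carries a bromo, but it reports a limit and differs from compound 3 in more than one place, so it does not bear on this exchange.

With a single halogen-for-alkyl step at this place lying within the scatter, the expected step of no change at the digits printed from compound 3 to compound 4 (within the scatter) is none beyond the scatter. Compound 4 is therefore estimated at 1400 nM, within the range 500 nM to 4000 nM.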

Compound 4, half-maximal effective concentration: 2600 nM
Estimate against measurement, compound 4: 1.9-fold (0.27 log units) below; the measured number falls inside the stated range.
By their numbers in this assay, from the lowest: compounds 3, 2 and 4 (each within the scatter of the next). At a limit, above all of these: compound 1.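

In this assay, going by these compounds alone, the first exchange of chloro for bromo at this place, on an aromatic carbon next to the ring nitrogen and para to a group of 8 heavy atoms, gives a 1.9-fold higher number from compound 3 to compound 4 (0.27 log units; within the scatter). The comparison with the methyl compound gives a 1.2-fold higher number from compound 2 to compound 4 (0.07 log units; within the scatter), so methyl, chloro and bromo at this place now form a set of three substituents linked by steps that all lie within the scatter, and no order among compound 2, compound 3 and compound 4 is claimed. Nothing measured in the series offers a reason for these steps or bears on this exchange.

On these data alone, all three substituents at this place are methyl or halogen, so it remains open whether a group of another kind there, such as an amine, a carboxylic acid or a longer alkyl chain, would move the number in this assay beyond the scatter. Compound 1 reports only a limit, > 1000000 nM, which supplies no number to set against the others.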